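From Piperidin-1-yl to 4-Ethylpiperazin-1-yl on the Carbonyl

The source may hold more compounds than are shown below. What is called first, only, known or untested is meant among the compounds shown, and "the series" means these compounds.

Measured so far in a functional assay on KARPAS-299 cells (Homo sapiens) for antiproliferative activity, read by MTT assay, with a stated time of 4 h; a higher number here means a weaker inhibitor, a lower number a stronger inhibitor:
compound 1, `COC(=O)c1cccn1-c1ccc(Nc2ncc(Cl)c(Nc3ccccc3NS(C)(=O)=O)n2)c(OC)c1`: 790 nM
compound 2, `COc1cc(-n2cccc2C(=O)O)ccc1Nc1ncc(Cl)c(Nc2ccccc2NS(C)(=O)=O)n1`: 90 nM
compound 3, `COc1cc(-n2cccc2C(=O)N2CCCCC2)ccc1Nc1ncc(Cl)c(Nc2ccccc2NS(C)(=O)=O)n1`: 1040 nM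

Compound 3 has the highest number of the three. Its nearest neighbour is compound 1, and the step of a 1.3-fold higher number from compound 1 to compound 3 (0.12 log units; within the scatter) lies within the scatter, so the two cannot be told apart. The gap to compound 2 is wider, as a 12-fold higher number from compound 2 to compound 3 (1.06 log units; beyond the scatter) shows.

Compound 4, `CCN1CCN(C(=O)c2cccn2-c2ccc(Nc3ncc(Cl)c(Nc4ccccc4NS(C)(=O)=O)n3)c(OC)c2)CC1`, differs from compound 3 in one place: 4-ethylpiperazin-1-yl in place of piperidin-1-yl on a carbonyl carbon. For the measured compounds named here, none of the measured steps exchanges one such ring for another on the carbonyl carbon. The steps that come closest are those into compound 3: methoxy to piperidin-1-yl, a 1.3-fold higher number from compound 1 to compound 3 (0.12 log units; within the scatter), within the scatter, and hydroxy to piperidin-1-yl, a 12-fold higher number from compound 2 to compound 3 (1.06 log units; beyond the scatter), large. Only the hydroxy group, in compound 2, stands apart, as an 8.8-fold lower number from compound 1 to compound 2 (0.94 log units; beyond the scatter) also shows; compound 1 and compound 3 sit together. Compound 4 keeps a ring on the carbonyl carbon, and the measured steps give no reason to expect a move beyond the scatter. For compound 4 the expected step is therefore small, a 1.2-fold lower number from compound 3 to compound 4 (0.06 log units; within the scatter). Compound 4 is estimated at 900 nM, in a range from 300 nM to 3000 nM.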

Compound 4, half-maximal inhibitory concentration: 1410 nM
Beside the measured number, compound 4's estimate is 1.6-fold (0.19 log units) below it, within the range that was stated.
By their numbers in this assay, from the lowest: compound 2; then compounds 1, 3 and 4 (each within the scatter of the next).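

Exchanging piperidin-1-yl for 4-ethylpiperazin-1-yl on the carbonyl carbon brings a second ring nitrogen, an ethyl group and a hydrogen-bond acceptor, yet in this assay the result is a 1.4-fold higher number from compound 3 to compound 4 (0.13 log units; within the scatter) and cannot be told apart from repeat scatter. The methyl ester and this new amide also sit together, with a 1.8-fold higher number from compound 1 to compound 4 (0.25 log units; within the scatter) as the step between them, whereas the carboxylic acid stands clearly apart, as a 16-fold higher number from compound 2 to compound 4 (1.19 log units; beyond the scatter) shows, so across these four compounds only hydroxy on the carbonyl carbon gives a number beyond the scatter from the rest. No measurement available here accounts for why the acid differs or why the two rings cannot be separated.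

Still open, on these data alone, is whether a morpholin-4-yl ring, a piperazin-1-yl ring without the ethyl group or a simple primary amide on the carbonyl carbon would stay with compounds 1, 3 and 4 or move towards compound 2. The compounds shown also leave open whether the difference of the acid holds when a longer chain places the carboxylic acid further from the carbonyl carbon's aromatic neighbour.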